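A few compounds are considered here, and "the series" means these few. Any claim that something is new, unique, unknown or untested is made for them only; others in the source may bear on it.

Measured so far:
Compound 1 `O=C1C=C(N2CCC2)C(=O)c2c1nc1n2[C@H]2OC[C@@H](O)[C@H]2OC1`: in a functional assay on MGC-803 cells (Homo sapiens) for inhibition, read by sulforhodamine B assay (a lower number here means a stronger inhibitor, a higher number a weaker inhibitor), compound 1 gives > 16000 nM, which is a limit of the assay and not a number.
Compound 2 `COc1ccccc1NC1=CC(=O)c2c(nc3n2[C@H]2OC[C@@H](O)[C@H]2OC3)C1=O`: in this assay compound 2 gives 1670 nM.
Compound 3 `CCOc1ccc(NC2=CC(=O)c3nc4n(c3C2=O)[C@H]2OC[C@@H](O)[C@H]2OC4)cc1`: in this assay compound 3 gives 1110 nM.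

Of the two numbers shown, compound 2 holds the higher one; compound 3 sits within the scatter of it, so no order between the two is claimed. Compound 1 is known only as a limit (the limit of > 16000 nM in this assay, at which 1 of the 3 values shown sits).

Compound 4 `O=C1C(Nc2cccc(Cl)c2)=CC(=O)c2c1nc1n2[C@H]2OC[C@@H](O)[C@H]2OC1` has not yet been measured. It differs from compound 2 in one place: 3-chlorophenyl in place of 2-methoxyphenyl on an amine nitrogen. Among the measured compounds shown here, no step between measured compounds bears on this change, and the two measured compounds that carry a substituted phenyl on the amine nitrogen, compound 2 and compound 3, lie within the scatter of each other, so there is nothing to suggest a large move. The expected step from compound 2 to compound 4 is a 1.2-fold lower number from compound 2 to compound 4 (0.08 log units; within the scatter), not beyond the scatter in either direction. Compound 4 is therefore estimated at 1400 nM, with a range from 450 nM to 4500 nM.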

Compound 4, half-maximal inhibitory concentration: 1530 nM
Compound 4: middle estimate off by 1.1-fold (0.04 log units), on the low side; measured number inside the range.
By their numbers in this assay, from the lowest: compounds 3, 4 and 2 (each within the scatter of the next). At a limit, above all of these: compound 1.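

In this assay, among the compounds shown here, 3-chlorophenyl in place of 2-methoxyphenyl on the amine nitrogen gives a 1.1-fold lower number from compound 2 to compound 4 (0.04 log units; within the scatter) and is the first step read directly at this position. The exchange removes the methoxy group and brings in a chlorine, yet the number stays within the scatter, so this change leaves the reading in this assay effectively flat. Nothing shown gives a cause for this result.

Compound 1 remains a limit of the assay and not a number: the limit of > 16000 nM in this assay, at which 1 of the 4 values shown sits. Still open, going by these compounds, is whether a phenyl carrying a carboxylic acid or an amine, or a longer alkyl chain on the nitrogen, would move the number beyond the scatter, and whether 2-chlorophenyl or 3-methoxyphenyl would separate the group from its place on the phenyl.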